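Aryl swap on the saturated ring carbon

The source may hold more compounds than are shown below. What is called first, only, known or untested is meant among the compounds shown, and "the series" means these compounds.

Compound 1 `O=C1NC(=O)/C(=C\c2ccc(OCC(=O)N3N=C(c4ccccc4)CC3c3ccc(F)cc3F)cc2)S1` gives 34000 nM in an assay on cells for inhibition of histone deacetylase 8 (Homo sapiens), read by fluorescence, with a stated time of 30 min; on this read-out lower numbers stand for stronger inhibition and higher numbers for weaker inhibition. Compound 2 `O=C1NC(=O)/C(=C\c2ccc(OCC(=O)N3N=C(c4ccc(F)cc4)CC3c3ccccc3Cl)cc2)S1` reaches only the limit of this assay, > 50000 nM. Compound 3 `O=C1NC(=O)/C(=C\c2ccc(OCC(=O)N3N=C(c4ccc(F)cc4)CC3c3ccc(C(F)(F)F)cc3)cc2)S1` likewise stops at a limit, > 50000 nM. The step that the two limits leave unreadable from compound 2 to compound 3 cannot be sized because both ends sit at the limit of > 50000 nM in this assay, at which 2 of the 3 values shown sit; compound 3 therefore stands on a limit only, and no readable step starts from it. Compound 4 `O=C1NC(=O)/C(=C\c2ccc(OCC(=O)N3N=C(c4ccc(F)cc4)CC3c3ccc(F)cc3F)cc2)S1` carries 2,4-difluorophenyl in place of 4-(trifluoromethyl)phenyl on a saturated ring carbon. For the measured compounds named here, the only measured step bears on the change but is unreadable, so no direction can be drawn from it; compound 1, which also carries a 2,4-difluorophenyl on that carbon, gives a weak value close to the limit. Compound 4 is expected at 40000 nM, within 15000 nM to 120000 nM. The expected step of an at least 1.2-fold lower number from compound 3 to compound 4 (0.09 log units; that floor lies within the scatter) stays unreadable against the limit.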

Compound 4, half-maximal inhibitory concentration: > 50000 nM
Compound 4 was reported as a limit; the forecaster's own chance of this, stated with the estimate: 50%; middle value at least 1.2-fold (0.09 log units) away from the limit.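

In this assay compound 4 gives only a limit, > 50000 nM. With 2-chlorophenyl, 4-(trifluoromethyl)phenyl and 2,4-difluorophenyl on the saturated ring carbon, compound 2, compound 3 and compound 4 all stop at one limit, and the steps among them cannot be read: the limit of > 50000 nM in this assay, at which 3 of the 4 values shown sit.

For the compounds shown here, the one readable step, an at least 1.4-fold higher number from compound 1 to compound 4 (0.16 log units; that floor lies within the scatter), places fluoro in place of hydrogen on an aromatic carbon, and its floor stays within the scatter, so no effect of that change can be claimed.

Open, from the compounds shown here alone, is whether an amine or a carboxylic acid in place of the aryl group on this carbon would give a value clear of the limit.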